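The compounds below may be only part of what the source reports. "The series", "measured", "known", "first", "only" and "open" are said of these compounds alone.

Compound 1 `O=C(CN1CCN(c2nnc(Cc3ccccc3)c3ccccc23)CC1)Nc1c(F)cccc1F` is the weakest of the three measured compounds in a functional assay on MDA-MB-231 cells (Homo sapiens) for cytotoxicity, read by MTT assay, with a stated time of 72 h (a lower number here means a stronger inhibitor, a higher number a weaker inhibitor), where compound 1 gives 5490 nM, the highest number in the set. Compound 3 `Cc1cccc(Cl)c1NC(=O)CN1CCN(c2nnc(Cc3ccncc3)c3ccccc23)CC1` comes nearest, and in this assay compound 3 gives 2670 nM, while compound 2 `O=C(CN1CCN(c2nnc(Cc3ccncc3)c3ccccc23)CC1)Nc1ccc(Br)cc1` lies furthest away, with compound 2 giving 19 nM in this assay. Compound 2 and compound 1 differ in two places at once, so their values can only be set side by side. Among the compounds with values here, the one single-change step recorded, a 140-fold higher number from compound 2 to compound 3 (2.15 log units; beyond the scatter), shows that exchanging the group on the amide-type nitrogen can move the number a long way.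

Within the data shown here, compound 4 `Cc1ccc(NC(=O)CN2CCN(c3nnc(Cc4ccccc4)c4ccccc34)CC2)c(C)c1` keeps the rest of compound 1 and changes only that group: 2,4-dimethylphenyl in place of 2,6-difluorophenyl on an amide-type nitrogen. The step from compound 2 to compound 3 bears on this change, as it is also an exchange of the aryl group on the amide-type nitrogen, and it was large. Among the measured compounds shown here, the direction for compound 4 is less settled, since no measured step goes from 2,6-difluorophenyl to 2,4-dimethylphenyl; with compound 1 already the highest number, a lower number is expected, with wide uncertainty, as a 3.7-fold lower number from compound 1 to compound 4 (0.56 log units; beyond the scatter). Compound 4 is therefore estimated at 1500 nM, between 150 nM and 9000 nM.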

Compound 4, half-maximal inhibitory concentration: 181000 nM
Compound 4: middle estimate off by 120-fold (2.08 log units), on the low side; the whole stated range lies below it.
By their numbers in this assay, from the lowest: compound 2; then compound 3; then compound 1; then compound 4.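

The exchange of 2,6-difluorophenyl for 2,4-dimethylphenyl on the amide-type nitrogen gives a 33-fold higher number from compound 1 to compound 4 (1.52 log units; beyond the scatter) in this assay and so takes the core of compound 1 further up from a number that was already the highest of the first three. The earlier compounds had shown a large step at this position only on the core shared by compound 2 and compound 3, so this result shows that the position is just as sensitive on the core of compound 1, and that a large rise in the number is possible there. The change also leaves every count computed for the group as it was, with the same number of heavy atoms, one six-membered aromatic ring of carbon only, no hydrogen-bond donors or acceptors and no net charge, so those counts do not track the step.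

The swap replaces both fluorine atoms and moves the substituents in one move, which leaves open how a single methyl, a single fluorine, a 4-bromophenyl, or an aryl group carrying an amine or a carboxylic acid would read on the core of compound 1. Nothing measured here explains why this exchange has so large an effect.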